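A Small Rearrangement in an Amino Acyl Group

This account rests on a few compounds, and the source may have more. Where it says the series, first, only, none or still open, it means among the compounds named here.

In a functional assay on HCT-116 cells (Homo sapiens) for antiproliferative activity (a higher number here means a weaker inhibitor, a lower number a stronger inhibitor), compound 2 (`CC[C@H](N)C(=O)N1CCc2c(C)c3c(n2-c2ccc(C(N)=O)c(c2)N[C@@H](C)[C@H](C)C1)CC(C)(C)CC3=O`) gives 33 nM and compound 1 (`Cc1c2c(n3c1CCN(C)C[C@@H](C)[C@H](C)Nc1cc-3ccc1C(N)=O)CC(C)(C)CC2=O`) gives 27 nM which places the two within the usual scatter of each other. Compound 3 (`Cc1c2c(n3c1CCN(C(=O)C(C)(C)N)C[C@@H](C)[C@H](C)Nc1cc-3ccc1C(N)=O)CC(C)(C)CC2=O`) has 1-amino-1-methylethyl in place of 1-aminopropyl on a carbonyl carbon. Going by the values given here, the one measured step that bears on this is a 1.2-fold higher number from compound 1 to compound 2 (0.09 log units; within the scatter) and it replaced methyl on an amine nitrogen in a ring with a whole (1-aminopropyl)carbonyl. Judging from that step, the expected change is no change at the digits printed from compound 2 to compound 3 (within the scatter) and nothing beyond the scatter is expected in either direction. Compound 3 is estimated at 33 nM with an expected range (14 nM to 75 nM).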

Compound 3, half-maximal inhibitory concentration: 25 nM
Beside the measured number, compound 3's estimate is 1.3-fold (0.12 log units) above it, and the stated range covers the measured number.
By their numbers in this assay, from the lowest: compounds 3, 1 and 2 (each within the scatter of the next).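

In this assay the change from 1-aminopropyl to 1-amino-1-methylethyl on a carbonyl carbon gives a 1.3-fold lower number from compound 2 to compound 3 (0.12 log units; within the scatter), so this rearrangement of the same atoms, which also loses the group's defined stereocentre, stays within the scatter. Swapping the methyl on the ring nitrogen for (1-amino-1-methylethyl)carbonyl gives a 1.1-fold lower number from compound 1 to compound 3 (0.03 log units; within the scatter), also within the scatter. Nothing available explains this result.

From the compounds shown here alone, whether the amine of these acyl groups matters remains open, and a plain acetyl group would test that. A carboxylic acid in its place is equally untested among these compounds.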